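Swapping the Amine Substituent: From Piperazine to Hydroxypiperidine

This account rests on a few compounds, and the source may have more. Where it says the series, first, only, none or still open, it means among the compounds named here.

Measured compounds:
- Compound 1 `Cc1nc(N2CCC(C)(O)CC2)nc2ccc(NC(=O)COc3ccc(Cl)cc3)cc12`: 827 nM
- Compound 2 `CCN1CCN(c2nc(C)c3cc(NC(=O)COc4ccc(Cl)cc4)ccc3n2)CC1`: "not determined" (no result reported)
- Compound 3 `Cc1nc(N2CCN(C)CC2)nc2ccc(NC(=O)COc3ccc(Cl)cc3)cc12`: 3800 nM

Three compounds share one core and differ only in the saturated amine attached to it. In a functional assay on CHO-K1 cells for antagonist activity at melanin-concentrating hormone receptor 1 (Homo sapiens), read by inositol phosphate accumulation (on this read-out higher numbers stand for weaker inhibition and lower numbers for stronger inhibition), compound 1 gives 827 nM. For compound 2 the outcome in this assay is "not determined" (no result reported), so it contributes no number. Among the compounds with values here, compound 3 gives 3800 nM in this assay, the highest of the two numbers available; its only neighbour with a number is compound 1, and the single measured step, a 4.6-fold higher number from compound 1 to compound 3 (0.66 log units; beyond the scatter), separates them.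

Compound 4 `Cc1nc(N2CCC(O)CC2)nc2ccc(NC(=O)COc3ccc(Cl)cc3)cc12` has not been measured. It differs from compound 3 by 4-hydroxypiperidin-1-yl in place of 4-methylpiperazin-1-yl on an aromatic carbon. Within the data shown here, the one step that bears on this change is a 4.6-fold higher number from compound 1 to compound 3 (0.66 log units; beyond the scatter), which runs in the opposite direction and gives a group close to the one entering here. The step from compound 3 to compound 4 is therefore expected to roughly undo it: a 3.8-fold lower number from compound 3 to compound 4 (0.58 log units; beyond the scatter). Compound 4 is accordingly estimated at 1000 nM, with a range from 400 nM to 2500 nM.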

Compound 4, half-maximal inhibitory concentration: 163 nM
For compound 4 the middle estimate is 6.1-fold (0.79 log units) above the measured one, outside the stated range (below it).
By their numbers in this assay, from the lowest: compound 4; then compound 1; then compound 3.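

In this assay, 4-hydroxypiperidin-1-yl in place of 4-methylpiperazin-1-yl gives a 23-fold lower number from compound 3 to compound 4 (1.37 log units; beyond the scatter), a far larger step than the earlier comparison of the two amines had suggested. The methyl group on the hydroxyl-bearing ring carbon also proves to matter, since hydrogen in its place gives a 5.1-fold lower number from compound 1 to compound 4 (0.71 log units; beyond the scatter), so the earlier step had understated what this amine position can gain. Nothing available explains either step.

The compounds shown do not separate the loss of the piperazine ring nitrogen from the gain of the hydroxyl, which a plain piperidine or a 4-methoxypiperidine would help to resolve. They also leave open how a 4-aminopiperidine or an ethyl group on that same ring carbon would read.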